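Swapping 3-fluorophenyl for isobutyl in compound 3

The source may hold more compounds than are shown below. What is called first, only, known or untested is meant among the compounds shown, and "the series" means these compounds.

compound 1 `O=C1Nc2ccc(F)cc2/C1=C\C(=O)c1ccc(O)cc1F`: 3440 nM
compound 2 `O=C1Nc2ccc(F)cc2/C1=C\C(=O)c1cnc2ccc(Cl)nn12`: 3090 nM
compound 3 `CN1CCN(c2cccc(N/C=C3\C(=O)Nc4ccc(NC(=O)c5cccc(F)c5)cc43)c2)CC1`: 6720 nM

These values come from a functional assay on HepG2 cells (Homo sapiens) for inhibition, read by sulforhodamine B assay, with a stated time of 3 days; a lower number here means a stronger inhibitor, a higher number a weaker inhibitor. Compound 3 cannot be told apart from compound 1, as their values lie within the scatter, but it is a weaker inhibitor than compound 2, beyond the scatter. Compound 4 `CC(C)CC(=O)Nc1ccc2c(c1)/C(=C/Nc1cccc(N3CCN(C)CC3)c1)C(=O)N2` has isobutyl in place of 3-fluorophenyl on a carbonyl carbon. Among the compounds with values here, no measured pair shows how a change like this acts in this assay, so the expectation is only a cautious one. The expected step is small, a 1.1-fold lower number from compound 3 to compound 4 (0.05 log units; within the scatter), with no shift beyond the scatter in either direction. For compound 4 the estimated value is 6000 nM, with an expected range from 2000 nM to 18000 nM.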

Compound 4, half-maximal inhibitory concentration: 5070 nM
Beside the measured number, compound 4's estimate is 1.2-fold (0.07 log units) above it, and the stated range covers the measured number.
By their numbers in this assay, from the lowest: compounds 2, 1, 4 and 3 (each within the scatter of the next, the first and the last beyond it).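

In this assay, putting isobutyl in place of 3-fluorophenyl on the carbonyl carbon gives a 1.3-fold lower number from compound 3 to compound 4 (0.12 log units; within the scatter) and this step lies within the scatter. The aromatic ring and the fluorine can therefore both go at this position with no shift that this assay can tell apart. No measurement at hand explains this result.

Both groups shown have no hydrogen-bond donors or acceptors. Going by these compounds, whether an amine or a carboxylic acid on the same carbonyl carbon would move the number remains open.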